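The source may report more compounds than this note shows. Statements on the series, on what has been measured and on what is new or still open speak of the compounds shown alone.

Measured compounds:
- compound 1 `CC(=O)Oc1c(C)cc(Cl)c2c1C(=O)C=CC2=O` gives 21800 nM in a functional assay on HeLa cells (Homo sapiens) for cytotoxicity, read by XTT assay, with a stated time of 24 h; on this read-out higher numbers stand for weaker inhibition and lower numbers for stronger inhibition
- compound 2 `CCOc1cc(C)cc2c1C(=O)C=CC2=O` gives 29700 nM in this assay

On these two numbers compound 1 sits close to compound 2; their gap lies within the usual scatter, so neither can be set apart from the other. Compound 3 `CCOc1c(C)cc(Cl)c2c1C(=O)C=CC2=O` is not yet measured. It differs from compound 1 in one place: ethyl in place of acetyl on an oxygen on an aromatic ring. Among the compounds with values here, no pair of measured compounds shows exactly this step, so its size is not known from direct comparison. What the two measured values do show is that compound 2, which carries the ethoxy group already, lies close to compound 1; on that basis no step beyond the scatter is expected in either direction. Compound 3 is therefore estimated at 25000 nM, within a range of 10000 nM to 60000 nM, which means an expected step of a 1.1-fold higher number from compound 1 to compound 3 (0.06 log units; within the scatter).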

Compound 3, half-maximal inhibitory concentration: 33200 nM
Compound 3: the middle estimate sits 1.3-fold (0.12 log units) below what was measured; low and high end bracket the measured number.
By their numbers in this assay, from the lowest: compounds 1, 2 and 3 (each within the scatter of the next).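

With the rest of the core of compound 1 held constant, replacing acetyl with ethyl on the oxygen on the aromatic ring gives a 1.5-fold higher number from compound 1 to compound 3 (0.18 log units; within the scatter) in this assay. This is the first comparison shown that isolates this position, and it shows that acetoxy and ethoxy cannot be told apart here, even though the change removes a carbonyl and its hydrogen-bond acceptor. No measurement shown accounts for this result, so it remains an observation without an explanation.

This single step does not show whether a longer chain, a carboxylic acid or an amine on this oxygen would also stay within the scatter. It also leaves open whether a free hydroxyl group there, or the same exchange on a different core, would give a similar result.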